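Working notes: cyano in place of ethynyl

The compounds below may be only part of what the source reports. "The series", "measured", "known", "first", "only" and "open" are said of these compounds alone.

- compound 1 `C#Cc1cccc(Nc2ncnc3cc(NC(=O)/C=C/c4ccccc4)sc23)c1` gives 2340 nM as its value
- compound 2 `O=C(/C=C/c1ccc(O)cc1)Nc1cc2c(Nc3ccc(Cl)c(Cl)c3)ncnc2s1` gives 1980 nM as its value

Among the compounds with values here, both values come from a functional assay on MDA-MB-231 cells (Homo sapiens) for antiproliferative activity, read by MTT assay, with a stated time of 48 h (on this read-out lower numbers stand for stronger inhibition and higher numbers for weaker inhibition), and are the only measurements so far. Compound 1 has the higher of the two numbers, but compound 2 lies within the scatter of it, so the two values set no order. They simply place the series at a single level in this assay for now.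

The next compound to be read is compound 3 `N#Cc1cccc(Nc2ncnc3cc(NC(=O)/C=C/c4ccccc4)sc23)c1`, which carries cyano in place of ethynyl on an aromatic carbon, meta to a large group (cyano in place of ethynyl on an aromatic carbon). The rest of compound 1 is unchanged. Within the data shown here, no measured step shows what this exchange does, so any expectation rests on compound 1 at 2340 nM as the sole anchor. The expected outcome is a 1.3-fold higher number from compound 1 to compound 3 (0.11 log units; within the scatter), a small move toward weaker inhibition that may well not exceed the scatter. Compound 3 is estimated at 3000 nM, with 1100 nM to 8000 nM as the expected range.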

Compound 3, half-maximal inhibitory concentration: 1040 nM
Estimate against measurement, compound 3: 2.9-fold (0.46 log units) above; the whole stated range lies above it.
By their numbers in this assay, from the lowest: compounds 3, 2 and 1 (each within the scatter of the next, the first and the last beyond it).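

In this assay, cyano in place of ethynyl on an aromatic carbon, meta to a large group, gives a 2.3-fold lower number from compound 1 to compound 3 (0.35 log units; beyond the scatter). Within the data shown here, this is the first single-place comparison, and it shows that this position responds to the exchange by more than the scatter, which compound 1 and compound 2 could not show as they differ in more than one place. The exchange keeps the count of 2 heavy atoms and the triple bond outside aromatic rings, while a nitrogen replaces a carbon and cyano has 1 hydrogen-bond acceptor against 0 for ethynyl, but no measurement on hand connects any of these differences to the lower number.

Among these compounds, the series so far holds one exchange at one position in one cell assay, so whether the lower number is particular to cyano or would also appear with an amine, a methoxy group or a carboxylic acid at the same place remains open. As far as these compounds go, it also remains open whether the same exchange gives a step of similar size when the rest of the molecule differs from compound 1.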